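A Changed Amine Group on a Shared Core

The source may report more compounds than this note shows. Statements on the series, on what has been measured and on what is new or still open speak of the compounds shown alone.

Compound 1 `CN(Cc1cccs1)C1CCN(CCCc2c[nH]c3ccc(-n4cnnc4)cc23)CC1` and compound 2 `OC[C@H](NC1CCN(CCCc2c[nH]c3ccc(Cn4cncn4)cc23)CC1)c1ccccc1` were both tested in an assay on CHO cells for displacement of a labelled ligand from 5-hydroxytryptamine receptor 1D (Homo sapiens); a lower number here means a stronger inhibitor, a higher number a weaker inhibitor. Compound 1 gives 4.3 nM, the lowest of the two numbers, while compound 2 gives 23 nM, a weaker result that lies beyond the usual scatter. Compound 3 `c1cncc(CNC2CCN(CCCc3c[nH]c4ccc(-n5cnnc5)cc34)CC2)c1` has not yet been measured. It differs from compound 1 in one place: ((pyridin-3-yl)methyl)amino in place of methyl((thiophen-2-yl)methyl)amino on a saturated ring carbon. Among the measured compounds shown here, no measured pair shows this exact change, so its effect is unknown. Compound 3 is expected to show a small loss in this assay, a 1.9-fold higher number from compound 1 to compound 3 (0.27 log units; within the scatter). The value estimated for compound 3 is 8 nM, within 3 nM to 25 nM.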

Compound 3, half-maximal inhibitory concentration: 35 nM
Compound 3: the middle estimate sits 4.4-fold (0.64 log units) below what was measured; measured number above the stated range.
By their numbers in this assay, from the lowest: compound 1; then compounds 2 and 3 (each within the scatter of the next).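

In this assay the amine group on a saturated ring carbon proves sensitive, with the swap to ((pyridin-3-yl)methyl)amino giving an 8.1-fold higher number from compound 1 to compound 3 (0.91 log units; beyond the scatter) despite an equal heavy-atom count. This single step replaces the thiophene ring with a pyridine ring and also adds a hydrogen-bond donor on the amine, so it cannot assign the loss to either part. Nothing shown here explains the loss.

The compounds shown leave open which part matters. The ((thiophen-2-yl)methyl)amino group or the methyl((pyridin-3-yl)methyl)amino group on the same core would separate the two.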